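Working notes: from compound 2 to compound 3

The source may hold more compounds than are shown below. What is called first, only, known or untested is meant among the compounds shown, and "the series" means these compounds.

Compound 1 `OCCCCCC(O)c1ccc(-c2ccccc2)cc1` at 22000 nM
Compound 2 `OCCCCCC(O)c1ccc(-c2ccc(Br)cc2)cc1` at 20000 nM

Going by the values given here, in a functional assay on J774 cells (Mus musculus) for cytotoxicity, read by resazurin assay (a lower number here means a stronger inhibitor, a higher number a weaker inhibitor), the one measured step is a 1.1-fold lower number from compound 1 to compound 2 (0.04 log units; within the scatter) and so compound 2 stands level with compound 1, with no order between them. Compound 3 `OCCCCCC(O)c1ccc(-c2ccccc2F)cc1` follows from compound 2 through 2-fluorophenyl in place of 4-bromophenyl on an aromatic carbon and carries 2-fluorophenyl in place of 4-bromophenyl on an aromatic carbon. Among the compounds with values here, no measured compound carries the entering group, so the data speak to this change only indirectly. Compound 2 at 20000 nM and the bromo step a 1.1-fold lower number from compound 1 to compound 2 (0.04 log units; within the scatter) are the only anchor, and on that basis no step beyond the scatter is expected in this assay for this change. The expected step is a 1.1-fold higher number from compound 2 to compound 3 (0.02 log units; within the scatter) and it lies within the scatter. Compound 3 is estimated at 21000 nM with an expected range from 11000 nM to 40000 nM for a repeated measurement.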

Compound 3, half-maximal inhibitory concentration: 22000 nM
Beside the measured number, compound 3's estimate is 1.0-fold (0.02 log units) below it, and the stated range covers the measured number.
By their numbers in this assay, from the lowest: compounds 2, 1 and 3 (each within the scatter of the next).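

With 2-fluorophenyl in place of 4-bromophenyl on an aromatic carbon, this assay gives a 1.1-fold higher number from compound 2 to compound 3 (0.04 log units; within the scatter) and so does not separate the two groups. A fluoro group on the otherwise bare ring gives no change at the digits printed from compound 1 to compound 3 (within the scatter) and adds a second substituted compound that stays level with the unsubstituted compound 1, so that neither a change of halogen group nor a change of its place on this ring has yet produced a step beyond the scatter. No accompanying data bear on why these compounds stand level.

From the compounds shown here alone, whether an amine or a carboxylic acid on this ring would give a step beyond the scatter in this assay remains open. A longer chain on the shared core is equally untested in the compounds shown, so the part of the structure that governs this read-out is still unknown.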